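From compound 1 to compound 4: one group exchanged

A few compounds are considered here, and "the series" means these few. Any claim that something is new, unique, unknown or untested is made for them only; others in the source may bear on it.

In a functional assay on SW-620 cells (Homo sapiens) for antiproliferative activity, read by MTT assay, with a stated time of 72 h (a higher number here means a weaker inhibitor, a lower number a stronger inhibitor), compound 1 `O=C1O/C(=C\Cn2cnc3cncc(Br)c32)C(OCc2ccccc2)=C1OCc1ccccc1` gives 32900 nM, and compound 2 `O=C1NC(O)(/C=C\n2cc(I)c3c(Cl)ncnc32)C(OCc2ccccc2)=C1OCc1ccccc1` gives 46900 nM. These two values lie within the usual scatter of each other, so they count as level. Compound 3 `O=C1NC(O)(CCn2cnc3cncc(Br)c32)C(OCc2ccccc2)=C1OCc1ccccc1` gives only a limit of the assay, > 100000 nM.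

Compound 4 `O=C1O/C(=C\Cn2cnc3c(Cl)c(F)nc(F)c32)C(OCc2ccccc2)=C1OCc1ccccc1` keeps the rest of compound 1 and exchanges one group: a group of 12 heavy atoms (6 carbon, 3 nitrogen, 2 fluorine, 1 chlorine; one five-membered aromatic ring with 2 hetero atoms, one six-membered aromatic ring with 1 hetero atom) in place of a group of 10 heavy atoms (6 carbon, 3 nitrogen, 1 bromine; one five-membered aromatic ring with 2 hetero atoms, one six-membered aromatic ring with 1 hetero atom), on a saturated chain carbon bound to a double-bonded chain carbon. Bromine leaves, while fluorine and chlorine enter, and the two aromatic rings of the group remain of the same sizes.

Among the measured compounds shown here, no two measured compounds differ in just one place, so the data give no direct guide to the size of this step. The best starting point is compound 1 at 32900 nM, and no change beyond the scatter is expected in this assay. The expected step is a 1.3-fold lower number from compound 1 to compound 4 (0.12 log units; within the scatter). The estimated value for compound 4 is 25000 nM, with an expected range from 8000 nM to 80000 nM.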

Compound 4, half-maximal inhibitory concentration: 50000 nM
Beside the measured number, compound 4's estimate is 2.0-fold (0.30 log units) below it; measured number inside the range.
By their numbers in this assay, from the lowest: compounds 1, 2 and 4 (each within the scatter of the next). At a limit, above all of these: compound 3.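

In this assay, among the compounds shown here, the first pair here that differs in only one place shows a 1.5-fold higher number from compound 1 to compound 4 (0.18 log units; within the scatter) and thus no change beyond the scatter. On a saturated chain carbon bound to a double-bonded chain carbon, the group carrying two fluorine atoms and one chlorine atom can therefore take the place of the group carrying bromine, with its two aromatic rings of the same sizes, and the number stays level. Nothing measured here gives a cause for this step.

Bromine leaves while fluorine and chlorine enter together, so this single step cannot separate the effect of each halogen. On these data alone, whether an amine or a carboxylic acid in place of these halogens, or a longer chain at this position, would move the number beyond the scatter stays open.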